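Adding a Methyl to the Benzyl Ring of Compound 2

The compounds below may be only part of what the source reports. "The series", "measured", "known", "first", "only" and "open" are said of these compounds alone.

Of the compounds shown here, two have been measured in a functional assay on RAW264.7 cells (Mus musculus) for inhibition, read by Griess assay, with stated times of 2 h and 24 h; on this read-out higher numbers stand for weaker inhibition and lower numbers for stronger inhibition. Compound 1 `CCn1cc(COc2cc(O)c3c(c2)O[C@H](c2ccc(OC)c(O)c2)C/C3=N\O)nn1` gives 3140 nM in this assay. Compound 2 `COc1ccc([C@@H]2CC(=O)c3c(O)cc(OCc4cn(Cc5ccccc5)nn4)cc3O2)cc1O` gives 11000 nM in this assay, the higher of the two numbers, and the gap between the two compounds lies beyond the scatter of repeated measurements. Compound 1 and compound 2 differ in more than one place. Nothing can be said about which part of their structures accounts for this gap.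

Compound 3 `COc1ccc([C@@H]2CC(=O)c3c(O)cc(OCc4cn(Cc5cccc(C)c5)nn4)cc3O2)cc1O` has not yet been measured. It differs from compound 2 in a single place: methyl in place of hydrogen on an aromatic carbon. Among the measured compounds shown here, the change is small, one carbon on the outer benzyl ring, and no measured pair shows what such a change does here. The step from compound 2 to compound 3 is therefore expected to be a 1.2-fold lower number from compound 2 to compound 3 (0.09 log units; within the scatter), that is, no change beyond the scatter. Compound 3 is estimated at 9000 nM in this assay, within a range of 4000 nM to 20000 nM.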

Compound 3, half-maximal inhibitory concentration: 17400 nM
Beside the measured number, compound 3's estimate is 1.9-fold (0.29 log units) below it; low and high end bracket the measured number.
By their numbers in this assay, from the lowest: compound 1; then compounds 2 and 3 (each within the scatter of the next).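

In this assay the change from benzyl to 3-methylbenzyl gives a 1.6-fold higher number from compound 2 to compound 3 (0.20 log units; within the scatter), so this one added carbon, meta to a large group, does not move the read-out past what repeated measurements would show. Among the compounds shown here, this is the only pair here that differs in one place, and it gives the first direct reading on the outer benzyl ring: this aromatic carbon can carry a methyl with no change that can be told from the scatter. Nothing measured here bears on the reason for this result.

One methyl says little about larger or different groups on this carbon. On these data alone, it remains open whether an amine, a carboxylic acid or a longer chain such as propyl in place of the methyl would shift the number beyond the scatter.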